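This account rests on a few compounds, and the source may have more. Where it says the series, first, only, none or still open, it means among the compounds named here.

Compound 3, `C=CC(=O)Nc1cccc(-n2c(-c3nc(-c4cnn(C5CCN(CC)CC5)c4)cnc3N)nc3ccccc32)c1`, belongs to a small set of close relatives. In a physicochemical assay for solubility, at pH 7.4 (on this read-out lower numbers stand for lower solubility and higher numbers for higher solubility), compound 3 gives only a limit of the assay, < 10000 nM, so its solubility is not known as a number. Compound 1, `C=CC(=O)Nc1cccc(-n2c(-c3nc(-c4cnn(C5CCN(C)CC5)c4)cnc3N)nc3ccccc32)c1`, likewise gives only a limit in this assay, < 10000 nM. For the measured compounds named here, compound 2, `C=CC(=O)Nc1cccc(-n2c(-c3nc(-c4cnn(CCN5CCN(C)CC5)c4)cnc3N)nc3ccccc32)c1`, is the one member with a read number: in this assay compound 2 gives 30000 nM. The step of an at least 3.0-fold higher number from compound 1 to compound 2 (0.47 log units; beyond the scatter) and the step of an at least 3.0-fold lower number from compound 2 to compound 3 (0.47 log units; beyond the scatter) are both readable only as lower bounds, and the step that the two limits leave unreadable from compound 1 to compound 3 cannot be read at all, as the limit of < 10000 nM in this assay, at which 2 of the 3 values shown sit, makes plain.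

Compound 4, `C=CC(=O)Nc1cccc(-n2c(-c3nc(-c4cnn(C5CCN(C(C)C)CC5)c4)cnc3N)nc3ccccc32)c1`, is the next member, and the change from compound 3 is methyl in place of hydrogen on a saturated chain carbon bound to an amine nitrogen in a ring and a saturated chain carbon. Going by the values given here, the nearest precedent is the step from compound 1 to compound 3, where the same kind of addition gave no readable change because of the limit of < 10000 nM in this assay, at which 2 of the 3 values shown sit. Compound 4 is therefore expected to stand where compound 3 stands, with a step that the limit leaves unreadable from compound 3 to compound 4 in this assay not expected to be readable. The estimate for compound 4 in this assay is 5000 nM, within 1000 nM to 15000 nM.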

Compound 4, solubility: < 10000 nM
Compound 4: only a limit was reported (the forecaster's own chance of this, stated with the estimate: 70%); the middle value does not contradict the limit.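

Compound 4 gives only a limit of the assay in this assay, so 1-isopropylpiperidin-4-yl joins the 1-methylpiperidin-4-yl of compound 1 and the 1-ethylpiperidin-4-yl of compound 3 as a third group at this position without a read number. For the compounds shown here, the one readable step is an at least 3.0-fold lower number from compound 2 to compound 4 (0.47 log units; beyond the scatter), so the 2-(4-methylpiperazin-1-yl)ethyl group of compound 2 stands apart from isopropyl-bearing compound 4 as it did from compound 1 and compound 3. The steps among compound 1, compound 3 and compound 4 cannot be read, and no order among them can be given: the limit of < 10000 nM in this assay, at which 3 of the 4 values shown sit.

From the compounds shown here alone, how far these three compounds lie under the limit remains open. Also open, going by these compounds, is whether another chain at this position, such as 2-(morpholin-4-yl)ethyl, would give a read number like that of compound 2.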